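A 3-chlorophenyl group in place of 4-(dimethylamino)phenyl

A few compounds are considered here, and "the series" means these few. Any claim that something is new, unique, unknown or untested is made for them only; others in the source may bear on it.

Of the compounds shown here, three with a shared core have been measured in a functional assay on MCF7 cells (Homo sapiens) for cytotoxicity, read by sulforhodamine B assay; a lower number here means a stronger inhibitor of growth, a higher number a weaker inhibitor of growth. Compound 1 `CC1=CC[C@@H]([C@@](C)(O)CCCC(C)(C)NC=S)CC1` gives 16000 nM, compound 2 `CC1=CC[C@@H]([C@@](C)(O)CCCC(C)(C)NC(=S)N/N=C\c2ccc(C)cc2)CC1` gives 7230 nM, and compound 3 `CC1=CC[C@@H]([C@@](C)(O)CCCC(C)(C)NC(=S)N/N=C\c2ccc(N(C)C)cc2)CC1` gives 14000 nM. Compound 3 therefore stands within the usual scatter of both other compounds, so its value cannot be ranked against either of them.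

Compound 4 `CC1=CC[C@@H]([C@@](C)(O)CCCC(C)(C)NC(=S)N/N=C\c2cccc(Cl)c2)CC1` has not yet been measured. It carries 3-chlorophenyl in place of 4-(dimethylamino)phenyl on a carbon with a double bond to nitrogen.

For the measured compounds named here, one measured step bears on this change: a 1.9-fold higher number from compound 2 to compound 3 (0.29 log units; within the scatter), with dimethylamino in place of methyl on an aromatic carbon. That step involves the same dimethylamino group that leaves here, and it stays within the scatter. Going by the values given here, no measured compound carries a 3-chlorophenyl group, so the data offer no direct reading of what it does. The expectation rests on the span from compound 2 at 7230 nM to compound 3 at 14000 nM. No step beyond the scatter is expected, and any drift is expected towards a lower number. The estimated move is a 1.6-fold lower number from compound 3 to compound 4 (0.19 log units; within the scatter). Compound 4 is estimated at 9000 nM, with an expected range from 4000 nM to 19000 nM.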

Compound 4, concentration for 50% growth inhibition: 7350 nM
For compound 4 the middle estimate is 1.2-fold (0.09 log units) above the measured one; low and high end bracket the measured number.
By their numbers in this assay, from the lowest: compounds 2, 4, 3 and 1 (each within the scatter of the next, the first and the last beyond it).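

In this assay, 3-chlorophenyl in place of 4-(dimethylamino)phenyl on a carbon with a double bond to nitrogen gives a 1.9-fold lower number from compound 3 to compound 4 (0.28 log units; within the scatter) and 3-chlorophenyl in place of 4-methylphenyl at the same place gives a 1.0-fold higher number from compound 2 to compound 4 (0.01 log units; within the scatter) as its result. This place has now carried three different aromatic groups, including the first with chlorine, and every step among them stays within the scatter, so compound 2, compound 3 and compound 4 cannot be ranked against one another. No evidence is at hand that would account for these numbers.

The 3-chlorophenyl group differs from the other two groups in both the substituent and the ring position given in its name, so the compounds shown do not separate these two changes, and 4-chlorophenyl or 3-methylphenyl would be needed to do so. Going by these compounds, it also remains open whether a group of another kind at this place, such as a carboxylic acid, an amine on a longer chain or a pyridine ring, would give a step beyond the scatter.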